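Phenylsulfanyl on the core of compound 1

This account rests on a few compounds, and the source may have more. Where it says the series, first, only, none or still open, it means among the compounds named here.

In a physicochemical assay for lipophilicity (a higher number here means a more lipophilic compound, a lower number a more polar compound), compound 1 `COc1c(OC)c(OC(C)=O)c2ccccc2c1OC(C)=O` gives 2.39. Going by the values given here, compound 2 `COc1ccc2c(OC(C)=O)c(OC)c(OC)c(OC(C)=O)c2c1` gives 2.39, so compound 1 stands level with the only other measured member of the series. Compound 3 `COc1c(OC)c(OC(C)=O)c2c(Sc3ccccc3)cccc2c1OC(C)=O` is the next to be read. It differs from compound 1 by a single change, phenylsulfanyl in place of hydrogen on an aromatic carbon.

Among the compounds with values here, one measured step bears on this change. It is also a replacement of hydrogen on an aromatic carbon, here by methoxy, and it shows no change at the digits printed from compound 1 to compound 2 (within the scatter). Within the data shown here, this is weak guidance, since methoxy is a different group and no measured compound carries phenylsulfanyl. The flat result for methoxy is therefore not carried over, and the expectation rests mainly on the size of the entering group, with its whole aromatic ring, no hydrogen-bond donors and no net charge. In this assay the expected step is a number 1.81 log units higher from compound 1 to compound 3 (beyond the scatter), upward and beyond the scatter. Compound 3 is expected at 4.2, with an estimated range of 3.6 to 4.8.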

Compound 3, partition coefficient: 4.2
For compound 3 middle estimate and measured number coincide at the digits printed; the range from low to high includes it.
By their numbers in this assay, from the lowest: compounds 1 and 2 (each within the scatter of the next); then compound 3.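

The result shows that replacing hydrogen on an aromatic carbon of the core of compound 1 need not leave the read-out flat: this assay shows a number 1.81 log units higher from compound 1 to compound 3 (beyond the scatter) with phenylsulfanyl, against no change at the digits printed from compound 1 to compound 2 (within the scatter) with methoxy. The core of compound 1 therefore takes a large step at a carbon ortho to a fused ring and meta to a fused ring, and across these two replacements the outcome differs with the entering group and, possibly, with the carbon that carries it. No measurement shown here accounts for the size of this step.

On these data alone, it remains open whether the step belongs to the sulfur link or to the attached phenyl ring, a question that phenoxy, methylsulfanyl or a directly attached phenyl on the same carbon would separate. Also open, as far as these compounds go, are how an amine or a carboxylic acid would read at this place, and whether phenylsulfanyl gives a step of similar size on the other aromatic carbons of the core.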